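The source may report more compounds than this note shows. Statements on the series, on what has been measured and on what is new or still open speak of the compounds shown alone.

Going by the values given here, compound 2 `CCOC(=O)C1=C(C)NC(=O)NC1c1cn(C(=O)CNc2ccc([N+](=O)[O-])cc2)c2ccccc12` gives 1.48 in a physicochemical assay for lipophilicity (on this read-out higher numbers stand for higher lipophilicity and lower numbers for lower lipophilicity), the lower of the two numbers known so far; compound 1 `CCOC(=O)C1=C(C)NC(=O)NC1c1cn(C(=O)CNc2ccc([N+](=O)[O-])cc2C)c2ccccc12` gives 1.94. Among the compounds with values here, the one measured step, a number 0.46 log units lower from compound 1 to compound 2 (beyond the scatter), touches a different part of the molecule. Compound 3 `CCOC(=O)C1=C(C)NC(=O)NC1c1cn(C(=O)CNc2ccccc2N)c2ccccc12` differs from compound 2 by 2-aminophenyl in place of 4-nitrophenyl on an amine nitrogen. Within the data shown here, no measured step covers this exchange, so the expectation rests on the change alone, and a drop beyond the scatter is expected, a number 0.88 log units lower from compound 2 to compound 3 (beyond the scatter). For compound 3 the estimated value in this assay is 0.6, within a range from 0 to 1.2.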

Compound 3, partition coefficient: 0.74
For compound 3 the middle estimate is 0.14 log units below the measured one, within the range that was stated.
By their numbers in this assay, from the lowest: compound 3; then compound 2; then compound 1.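

On the amine nitrogen, 2-aminophenyl in place of 4-nitrophenyl gives a number 0.74 log units lower from compound 2 to compound 3 (beyond the scatter) in this assay, so exchanging this aryl group moves the number beyond the scatter. Going by these compounds alone, with 2-aminophenyl in place of 2-methyl-4-nitrophenyl, the result is a number 1.20 log units lower from compound 1 to compound 3 (beyond the scatter), the only step here rated large. Nothing available explains the size of these steps.

Still open, from the compounds shown here alone, is how much of each step belongs to the nitro group leaving and how much to the amino group entering, as the two change together. Plain phenyl, or a carboxylic acid in place of the amine, could help separate them.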